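A few compounds are considered here, and "the series" means these few. Any claim that something is new, unique, unknown or untested is made for them only; others in the source may bear on it.

In an ADME assay on microsomes from liver (Mus musculus) for metabolic stability, with a stated time of 0.5 h (on this read-out lower numbers stand for a less stable compound and higher numbers for a more stable compound), three compounds have been measured. Compound 1 `COc1ccccc1-c1cccc(Cn2cnc3ccc(C(=O)NCc4cccc(F)c4)cc32)c1` gives 0% in this assay. Compound 2 `COc1cc(F)ccc1-c1cccc(Cn2ccc3ccc(NC(=O)CC(C)(C)O)cc32)n1` gives 44% in this assay. Compound 3 `COc1cc(F)ccc1-c1cccc(Cc2cn(C)c3ccc(NC(=O)C(C)(C)CO)cc23)n1` gives 5% in this assay, the second highest of the three numbers: its nearest neighbour is compound 1, whose number lies lower by a margin within the scatter, while compound 2 lies far above it, beyond the scatter.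

Compound 4 `COc1cc(F)ccc1-c1cccc(Cc2cn(C)c3ccc(NC(=O)CC(C)(C)O)cc23)n1` differs from compound 3 in one place: 2-hydroxy-2-methylpropyl in place of 1-(hydroxymethyl)-1-methylethyl on a carbonyl carbon. Going by the values given here, no measured pair of compounds shows this exact rearrangement, so its size in this assay is not known from the data. The expected step from compound 3 to compound 4 is a number 15 percentage points higher from compound 3 to compound 4 (beyond the scatter), upward but uncertain. Compound 4 is expected to give about 20%, within a range from 3% to 50%.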

Compound 4, percent of the compound remaining in the Mus musculus assay: 14%
Estimate against measurement, compound 4: 6 percentage points above; low and high end bracket the measured number.
By their numbers in the Mus musculus assay, from the lowest: compounds 1, 3 and 4 (each within the scatter of the next, the first and the last beyond it); then compound 2.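

In the Mus musculus assay, putting 2-hydroxy-2-methylpropyl in place of 1-(hydroxymethyl)-1-methylethyl on this carbonyl carbon gives a number 9 percentage points higher from compound 3 to compound 4 (within the scatter), so this rearrangement of the same atoms does not clearly separate the two compounds. In a physicochemical assay for solubility (on this read-out higher numbers stand for higher solubility and lower numbers for lower solubility), compound 3 gives 2000 ug/mL and compound 4 gives 10600 ug/mL. In the physicochemical assay, the same change does separate them, showing that how these atoms are joined at this place matters for solubility: the measured solubility of compound 3, 2000 ug/mL, and of compound 4, 10600 ug/mL, a 5.3-fold higher number (0.72 log units; beyond the scatter)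

Still open, on these data alone, is whether a longer chain ending in a hydroxyl, an amine or a carboxylic acid on this carbonyl carbon would change the number in the Mus musculus assay.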